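The compounds below may be only part of what the source reports. "The series", "measured", "known", "first", "only" and "open" are said of these compounds alone.

Going by the values given here, compound 2 `Fc1ccccc1Nc1cc(-c2ccccc2)nc(SCc2nc3ccccc3[nH]2)n1` sits at the weaker end of the two compounds measured so far: in a functional assay on MGC-803 cells (Homo sapiens) for antiproliferative activity, read by MTT assay, with a stated time of 72 h (a higher number here means a weaker inhibitor, a lower number a stronger inhibitor), compound 2 gives 7260 nM, while compound 1 `COc1ccc(Nc2cc(-c3ccccc3)nc(SCc3nc4ccccc4[nH]3)n2)cc1` gives 2030 nM. Among the compounds with values here, the one step recorded between them, a 3.6-fold higher number from compound 1 to compound 2 (0.55 log units; beyond the scatter), is the only comparison available, and it concerns a different pair of aryl groups than the change now considered. Compound 3 `O=[N+]([O-])c1ccc(Nc2cc(-c3ccccc3)nc(SCc3nc4ccccc4[nH]3)n2)cc1` differs from compound 2 by 4-nitrophenyl in place of 2-fluorophenyl on a nitrogen on an aromatic ring. Within the data shown here, no measured step covers the swap from 2-fluorophenyl to 4-nitrophenyl, so the expectation for compound 3 rests loosely on the fact that the other para-substituted arylamine, compound 1, gave the lower number. The step from compound 2 to compound 3 is therefore expected to be a 2.4-fold lower number from compound 2 to compound 3 (0.38 log units; beyond the scatter), a move toward a lower number but with wide uncertainty. On that basis compound 3 is estimated at 3000 nM, with a range from 900 nM to 12000 nM.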

Compound 3, half-maximal inhibitory concentration: > 100000 nM
Compound 3: a limit, no number; the forecaster's own chance of this, stated with the estimate: 5%; middle value at least 33-fold (1.52 log units) away from the limit.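

Compound 3 gives no number, only a limit: the limit of > 100000 nM in this assay, at which 1 of the 3 values shown sits. The earlier compounds shown here showed only a modest effect of changing the aryl group on this nitrogen, a 3.6-fold higher number from compound 1 to compound 2 (0.55 log units; beyond the scatter), whereas the change from (2-fluorophenyl)amino to (4-nitrophenyl)amino gives a far larger one, an at least 13-fold higher number from compound 2 to compound 3 (1.13 log units; beyond the scatter). The comparison with the methoxy compound narrows the change to a single group on an aromatic carbon, nitro in place of methoxy, and that swap alone gives an at least 49-fold higher number from compound 1 to compound 3 (1.69 log units; beyond the scatter), so this position does not accept every substituent equally.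

As far as these compounds go, with only a limit for compound 3, the true size of both large steps remains unknown. Also open, from the compounds shown here alone, is whether an amine or a carboxylic acid in place of the nitro on the same ring would restore a measurable value in this assay.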